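Ethylamino variant of compound 1: expected half-maximal effective concentration

The source may report more compounds than this note shows. Statements on the series, on what has been measured and on what is new or still open speak of the compounds shown alone.

Compound 1 `CCCN(CCC)Cc1ccc(Cl)c(-c2ccccc2OC)c1` is recorded in a functional assay on HEK293 cells for agonist activity at 5-hydroxytryptamine receptor 7 (Homo sapiens), read by a luciferase reporter and beta-arrestin recruitment, with a stated time of 22 h (on this read-out higher numbers stand for an effect only at larger amounts of compound and lower numbers for an effect already at smaller amounts), as "not active" (no number reported) with no single number, and two further entries likewise give none. Two related compounds carry numbers: compound 2 `COc1ccccc1-c1cc(C2CCNC2)ccc1Cl` gives 75.9 nM; 75 nM (2 entries) in this assay, and compound 3 `CNCc1ccc(Cl)c(-c2ccccc2OC)c1` gives 148 nM; 150 nM (2 entries). The repeated entries of compound 2 (the several entries of compound 2 in this assay, 75.9 nM; 75 nM (2 entries)) and of compound 3 (the several entries of compound 3 in this assay, 148 nM; 150 nM (2 entries)) agree closely. Compound 4 `CCNCc1ccc(Cl)c(-c2ccccc2OC)c1` is not yet measured; it differs from compound 1 by ethylamino in place of dipropylamino on a saturated chain carbon bound to an aromatic carbon. Going by the values given here, no step between measured compounds is available, so the move from compound 1 to compound 4 can only be expected: a gain, from no reported number to a measurable value. For compound 4 the estimate in this assay is 250 nM, with a range of 80 nM to 1500 nM.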

Compound 4, half-maximal effective concentration: "not active" (no number reported)
No number was reported for compound 4, and the estimate cannot be compared.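

Compound 1 gives "not active" (no number reported) and compound 4 gives "not active" (no number reported) in this assay, so no step can be read between them. Nothing recorded for the other compounds bears on this result. From the compounds shown here alone, how far compound 1 and compound 4 lie from a measurable value stays open.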